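A few compounds are considered here, and "the series" means these few. Any claim that something is new, unique, unknown or untested is made for them only; others in the source may bear on it.

Working notes on the series.

Compound 1 `N#CC1=C(N)Oc2c(c3nc4ccccc4nc3c3ccccc23)C12C(=O)N(Cc1cnnn1-c1ccc(N)cc1)c1ccccc12` carries a 4-aminophenyl on the aromatic nitrogen. In a functional assay on MCF7 cells (Homo sapiens) for antiproliferative activity, read by MTT assay, with a stated time of 48 h (a lower number here means a stronger inhibitor, a higher number a weaker inhibitor), compound 1 gives > 50000 nM, which is a limit of the assay and not a number. Compound 2 `Cc1ccc(-n2nncc2CN2C(=O)C3(C(C#N)=C(N)Oc4c3c3nc5ccccc5nc3c3ccccc43)c3ccccc32)c(C)c1` carries 2,4-dimethylphenyl in place of 4-aminophenyl on that nitrogen. In this assay compound 2 gives > 50000 nM, again a limit. The step that the two limits leave unreadable from compound 1 to compound 2 is therefore not readable. Compound 3 `Cc1cccc(-n2nncc2CN2C(=O)C3(C(C#N)=C(N)Oc4c(N)cc5nc6ccccc6nc5c43)c3ccccc32)c1` has an amino group on the shared core and a 3-methylphenyl on the aromatic nitrogen. In this assay compound 3 gives > 50000 nM, a limit as well. Compound 3 thus stands at the limit of > 50000 nM in this assay, at which 3 of the 3 values shown sit, with no number that separates it from the other two.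

Compound 4 `COc1ccc(-n2nncc2CN2C(=O)C3(C(C#N)=C(N)Oc4c(N)cc5nc6ccccc6nc5c43)c3ccccc32)cc1` differs from compound 3 by 4-methoxyphenyl in place of 3-methylphenyl on an aromatic nitrogen.

Among the measured compounds shown here, no measured step bears on this change: the one step available, from compound 1 to compound 2, is hidden by the two limits, and every value so far sits at the limit of > 50000 nM in this assay, at which 3 of the 3 values shown sit. The expectation is therefore that compound 4 also reports only a limit, and the step that the limit leaves unreadable from compound 3 to compound 4 is expected to stay within the scatter. Compound 4 is estimated at 60000 nM, with a range from 20000 nM to 200000 nM.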

Compound 4, half-maximal inhibitory concentration: > 50000 nM
Compound 4 ended at the assay's limit (the forecaster's own chance of this, stated with the estimate: 85%); the middle value is on the limit's open side.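

In this assay compound 4 gives > 50000 nM, a limit of the assay and not a number, so the step from compound 3 to compound 4 cannot be read, and the series stands as follows: the limit of > 50000 nM in this assay, at which 4 of the 4 values shown sit.

The compounds shown leave open whether any change on the aromatic nitrogen or on the shared core gives a measurable value in this assay.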